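A methoxy group on the core of compound 1

The compounds below may be only part of what the source reports. "The series", "measured", "known", "first", "only" and "open" are said of these compounds alone.

In a functional assay on DU-145 cells (Homo sapiens) for cytotoxicity, read by MTT assay, with a stated time of 72 h (on this read-out lower numbers stand for stronger inhibition and higher numbers for weaker inhibition), compound 1 `O=c1ccc2nc(-c3ccccc3)nn(-c3ccccc3)c-2c1` gives 230 nM and holds the lowest number of the three compounds measured. Compound 2 `Nc1cc2nc(-c3ccccc3)nn(-c3ccccc3)c-2cc1=O` has amino in place of hydrogen on an aromatic carbon and gives 1830 nM in this assay as a measured number. That change is an 8.0-fold higher number from compound 1 to compound 2 (0.90 log units; beyond the scatter) and counts as modest. Compound 3 `CC(=O)Nc1cc2nc(-c3ccccc3)nn(-c3ccccc3)c-2cc1=O` has acetamido in place of hydrogen on an aromatic carbon and gives > 5000 nM as a limit of the assay and not a number. That change is an at least 21-fold higher number from compound 1 to compound 3 (1.33 log units; beyond the scatter) and counts as large, while acetyl on the nitrogen of the amino group gives an at least 2.7-fold higher number from compound 2 to compound 3 (0.43 log units; beyond the scatter) as a further step.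

Compound 4 `COc1cc2nc(-c3ccccc3)nn(-c3ccccc3)c-2cc1=O` has not yet been measured. Its change is methoxy in place of hydrogen on an aromatic carbon and both measured changes of this kind raised the number. For the measured compounds named here, a modest rise is therefore expected because the amino step was an 8.0-fold higher number from compound 1 to compound 2 (0.90 log units; beyond the scatter) and gives the only measured size of step without a limit. The expected change is a 5.7-fold higher number from compound 1 to compound 4 (0.75 log units; beyond the scatter) and is estimated to lie beyond the scatter. In this assay the estimated value for compound 4 is 1300 nM with 400 nM and 4500 nM as the expected lower and upper ends.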

Compound 4, half-maximal inhibitory concentration: > 5000 nM
Compound 4 ended at the assay's limit; the forecaster's own chance of this, stated with the estimate: 10%; at least 3.8-fold (0.58 log units) between middle value and limit.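

In this assay compound 4 gives > 5000 nM as a limit of the assay and not a number. Methoxy on this aromatic carbon, a group with 0 hydrogen-bond donors, gives an at least 21-fold higher number from compound 1 to compound 4 (1.33 log units; beyond the scatter) and so the rise over hydrogen seen with amino and acetamido also appears with a group that carries no nitrogen, while the exchange of amino for methoxy gives an at least 2.7-fold higher number from compound 2 to compound 4 (0.43 log units; beyond the scatter) in the same place. The step between compound 3 and compound 4 cannot be read, because both sit at the same limit: the limit of > 5000 nM in this assay, at which 2 of the 4 values shown sit.

The compounds shown leave open how far methoxy and acetamido actually raise the number, and so which of the two costs more at this position. They also leave open whether any group on this aromatic carbon raises the number over hydrogen, a question that a fluorine atom, a methyl group or a hydroxyl group in the same place would bear on.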